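Shortening a hydroxyalkyl carbonate chain in cytotoxicity testing

The source may report more compounds than this note shows. Statements on the series, on what has been measured and on what is new or still open speak of the compounds shown alone.

Compound 3 `Cc1cn(C2CC(N=[N+]=[N-])C(COC(=O)OCCCCCO)O2)c(=O)[nH]c1=O` was tested in a functional assay on MT4 cells (Homo sapiens) for cytotoxicity; a higher number here means that more compound is tolerated, a lower number that less compound is tolerated. In this assay compound 3 gives only a limit, > 50000 nM. Compound 1 `Cc1cn(C2CC(N=[N+]=[N-])C(COC(=O)OCCCCCCO)O2)c(=O)[nH]c1=O` gives > 50000 nM in this assay, which is a limit. Compound 2 `Cc1cn(C2CC(N=[N+]=[N-])C(COC(=O)OCCCN)O2)c(=O)[nH]c1=O` gives > 50000 nM, again a limit. Because all three values share (the limit of > 50000 nM in this assay, at which 3 of the 3 values shown sit), the steps a step that the two limits leave unreadable from compound 1 to compound 3, a step that the two limits leave unreadable from compound 1 to compound 2 and a step that the two limits leave unreadable from compound 2 to compound 3 carry no readable size. Compound 4 `Cc1cn(C2CC(N=[N+]=[N-])C(COC(=O)OCCO)O2)c(=O)[nH]c1=O` has not yet been measured; it differs from compound 3 by hydroxy in place of 3-hydroxypropyl on a saturated chain carbon, two bonds along the chain from an oxygen next to a carbonyl group. The measured steps touching this part of the chain, a step that the two limits leave unreadable from compound 1 to compound 3 and a step that the two limits leave unreadable from compound 2 to compound 3, are both unreadable, so they point in no direction for this assay. Compound 4 is therefore expected to sit at the limit as well, and the expected step of a number no higher from compound 3 to compound 4 (the limit leaves the size open) is none beyond the scatter. Compound 4 is estimated at 50000 nM, with a range from 20000 nM to 200000 nM, and will most likely again be reported only as a limit.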

Compound 4, half-maximal cytotoxic concentration: > 50000 nM
Compound 4 was reported as a limit (the forecaster's own chance of this, stated with the estimate: 90%); the middle value sits exactly at the limit.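

Among the compounds shown here, compound 4 stands, like compound 1, compound 2 and compound 3, only as a limit in this assay, so no step to compound 4 can be read: the limit of > 50000 nM in this assay, at which 4 of the 4 values shown sit. The compounds shown leave open at what concentration any of them becomes cytotoxic, and whether the chain matters at all.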